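This account rests on a few compounds, and the source may have more. Where it says the series, first, only, none or still open, it means among the compounds named here.

Compounds measured in an assay on isolated protein for inhibition of glutathione S-transferase P (Homo sapiens), with a stated time of 10 min; a higher number here means a weaker inhibitor, a lower number a stronger inhibitor:
compound 1 `O=C(O)CCC(=O)OCCCCCCSc1ccc([N+](=O)[O-])c2nonc12` gives 530 nM
compound 2 `O=C(CCC(=O)OCCCCCCSc1ccc([N+](=O)[O-])c2nonc12)Nc1ccccc1Cl` gives 15500 nM
compound 3 `COc1ccc(NC(=O)CCC(=O)OCCCCCCSc2ccc([N+](=O)[O-])c3nonc23)cc1` gives 420 nM

Compound 3 gives the lowest number of the three, though its value and that of compound 1 lie within the scatter of each other, as a 1.3-fold lower number from compound 1 to compound 3 (0.10 log units; within the scatter) shows; only compound 2 stands clearly apart, with a 37-fold lower number from compound 2 to compound 3 (1.57 log units; beyond the scatter). Compound 4 `O=C(CCC(=O)OCCCCCCSc1ccc([N+](=O)[O-])c2nonc12)Nc1ccc(C(F)(F)F)cc1` differs from compound 3 by trifluoromethyl in place of methoxy on an aromatic carbon. Going by the values given here, no measured step touches this change directly; the one step on the aryl group, from compound 2 to compound 3, swaps both the substituent and its place, so it gives only a rough guide that the aryl substituent can matter. In this assay the step from compound 3 to compound 4 is therefore expected to be small, a 1.7-fold higher number from compound 3 to compound 4 (0.22 log units; within the scatter), with wide uncertainty. Compound 4 is estimated at 700 nM, between 200 nM and 3000 nM.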

Compound 4, half-maximal inhibitory concentration: 5050 nM
Compound 4: the middle estimate sits 7.2-fold (0.86 log units) below what was measured, and the stated range ends below it.
By their numbers in this assay, from the lowest: compounds 3 and 1 (each within the scatter of the next); then compound 4; then compound 2.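

In this assay the aryl substituent matters even when its place stays the same: a 12-fold higher number from compound 3 to compound 4 (1.08 log units; beyond the scatter) isolates trifluoromethyl in place of methoxy, a separation that the earlier step, which changed substituent and place together, could not make. The amide with the 4-(trifluoromethyl)phenyl group is also clearly apart from the acid, with a 9.5-fold higher number from compound 1 to compound 4 (0.98 log units; beyond the scatter) in this comparison, and from the 2-chlorophenyl amide, with a 3.1-fold lower number from compound 2 to compound 4 (0.49 log units; beyond the scatter) there. Nothing at hand accounts for these steps.

From the compounds shown here alone, what an amine or a nitrile in that place would give stays open, and so does how 4-chlorophenyl would compare with 2-chlorophenyl.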